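Ring-Amine Substituent Change and Cytotoxicity Across Two Cores

A few compounds are considered here, and "the series" means these few. Any claim that something is new, unique, unknown or untested is made for them only; others in the source may bear on it.

Compound 1 `Cc1cc(C)cc(S(=O)(=O)c2c(C(=O)N[C@@H]3CCN(Cc4ccccc4C#N)C3)[nH]c3ccc(Cl)cc23)c1` and compound 2 `Cc1cc(C)cc(S(=O)(=O)c2c(C(=O)N[C@@H]3CCN(S(C)(=O)=O)C3)[nH]c3ccc(Cl)cc23)c1` share one core; compound 3 `Cc1cc(C)cc(S(=O)(=O)c2c(C(=O)NC3CN(Cc4ccccc4C#N)C3)[nH]c3ccc(Cl)cc23)c1` and compound 4 `Cc1cc(C)cc(S(=O)(=O)c2c(C(=O)NC3CN(S(C)(=O)=O)C3)[nH]c3ccc(Cl)cc23)c1` share another, and the difference between the two cores is not broken down here. In an ADME assay on MT4 cells (Homo sapiens) for cytotoxicity, read by MTT assay, with a stated time of 5 days (on this read-out lower numbers stand for higher toxicity in this test and higher numbers for lower toxicity in this test), compound 1 gives >= 186000 nM, which is a limit of the assay rather than a number. In this assay compound 2 gives 24000 nM. The change methylsulfonyl in place of 2-cyanobenzyl on an amine nitrogen in a ring thus made an at least 7.7-fold lower number from compound 1 to compound 2 (0.88 log units; beyond the scatter); the true size of that step is bounded only by the limit of >= 186000 nM in this assay, at which 1 of the 3 values shown sits. In this assay compound 3 gives > 234000 nM, likewise a limit, as the limit of > 234000 nM in this assay, at which 1 of the 3 values shown sits, records. The same kind of change, (methylsulfonyl in place of 2-cyanobenzyl on an amine nitrogen in a ring), leads to compound 4; the place differs only in that the amine nitrogen sits in a four-membered non-aromatic ring with 1 nitrogen rather than a five-membered one. Given an at least 7.7-fold lower number from compound 1 to compound 2 (0.88 log units; beyond the scatter), the expected step is an at least 7.8-fold lower number from compound 3 to compound 4 (0.89 log units; beyond the scatter). Compound 4 is therefore estimated at 30000 nM in this assay, with a likely range of 10000 nM to 150000 nM.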

Compound 4, half-maximal cytotoxic concentration: > 252000 nM
Compound 4 was reported as a limit; the forecaster's own chance of this, stated with the estimate: 25%; middle value at least 8.4-fold (0.92 log units) away from the limit.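

In this assay compound 4 gives > 252000 nM, which is a limit of the assay and not a number. Compound 3 is also recorded as a limit, so the step between these two compounds cannot be read; the change of 2-cyanobenzyl to methylsulfonyl, which gave an at least 7.7-fold lower number from compound 1 to compound 2 (0.88 log units; beyond the scatter), yields no measured value in the core with the four-membered ring, and neither the size nor the direction of its effect there is shown. For the compounds shown here, the one readable step is an at least 10-fold higher number from compound 2 to compound 4 (1.02 log units; beyond the scatter), which shows that with methylsulfonyl held constant, the two cores do not give the same result, but this rests on a single pair and does not establish how the 2-cyanobenzyl change transfers between them.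

Still open, going by these compounds, is whether an acetyl or an unsubstituted benzyl on the ring amine nitrogen would give a readable number in either core. On these data alone, it also remains open whether the lower number of compound 2 is specific to methylsulfonyl or extends to other sulfonyl groups, such as ethylsulfonyl.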